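Fluorine removal on the glycerol carbon of a palmitoyl phosphate

The source may hold more compounds than are shown below. What is called first, only, known or untested is meant among the compounds shown, and "the series" means these compounds.

In an in vitro functional assay on Sf9 cells for agonist activity at lysophosphatidic acid receptor 3 (Homo sapiens), read by calcium flux (on this read-out higher numbers stand for an effect only at larger amounts of compound and lower numbers for an effect already at smaller amounts), compound 2 `CCCCCCCCCCCCCCCC(=O)OC[C@@H](F)COP(=O)(O)O` is reported only as a limit of the assay, > 10000 nM. Compound 1 `CCCCCCCC/C=C/CCCCCCCC(=O)OC[C@@H](F)COP(=O)(O)O` sits at the same limit, > 10000 nM. Compound 3 `CCCCCCCCCCCCCCCC(=O)O[C@H](COP(=O)(O)O)C(F)F` likewise gives only the limit > 10000 nM. Hence (the limit of > 10000 nM in this assay, at which 3 of the 3 values shown sit), and no numbered value places compound 2 anywhere within the series. Compound 4 `CCCCCCCCCCCCCCCC(=O)OCC(O)COP(=O)(O)O` is not yet measured in this assay. It differs from compound 2 by a group of 8 heavy atoms (2 carbon, 5 oxygen, 1 phosphorus; no ring) in place of a group of 8 heavy atoms (2 carbon, 4 oxygen, 1 fluorine, 1 phosphorus; no ring), on a saturated chain carbon bound to an oxygen next to a carbonyl group. Among the measured compounds shown here, with no measured step, the direction of the change cannot be read from compound 1 or compound 3. On the expectation that a number appears, the step of an at least 20-fold lower number from compound 2 to compound 4 (1.30 log units; beyond the scatter) is estimated as a gain in potency. Compound 4 is estimated at 500 nM, within 50 nM to 5000 nM.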

Compound 4, half-maximal effective concentration: > 10000 nM
Compound 4 ended at the assay's limit; the forecaster's own chance of this, stated with the estimate: 35%; middle value at least 20-fold (1.30 log units) from the limit.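

Compound 2 and compound 4 both give only a limit, so no step between them can be read: the limit of > 10000 nM in this assay, at which 4 of the 4 values shown sit.

The compounds shown leave open whether the exchange on this saturated chain carbon changes agonist potency at all.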